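The compounds below may be only part of what the source reports. "The series", "measured", "known", "first", "only" and "open" are said of these compounds alone.

The study concerns two small compounds built on a shared core, compound 1 `COc1cc(-c2nccn2C(C)C)cc(OC)c1OC` and compound 2 `COc1cc(-c2nccn2S(=O)(=O)c2ccccc2)cc(OC)c1OC`, both tested in a functional assay on MDA-MB-468 cells (Homo sapiens) for antiproliferative activity, read by MTT assay, with a stated time of 72 h; on this read-out higher numbers stand for weaker inhibition and lower numbers for stronger inhibition. In this assay compound 1 gives only a limit of the assay, > 100000 nM, and not a number. Compound 2 likewise returns only a limit, > 100000 nM. Within the data shown here, compound 1 therefore stands where every value shown stands, at the limit of > 100000 nM in this assay, at which 2 of the 2 values shown sit, so no measured step between two compounds exists and nothing about the size of any change can be read from the numbers so far.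

Compound 3 `COc1cc(-c2nccn2-c2ccc(Br)cc2)cc(OC)c1OC` has not yet been measured. It differs from compound 1 in one place: 4-bromophenyl in place of isopropyl on an aromatic nitrogen. Among the measured compounds shown here, with both measured compounds sitting at the limit, no direction for this step can be drawn from them, and the change itself carries no measured evidence either way. The step from compound 1 to compound 3 is expected to be a number no higher from compound 1 to compound 3 (the limit leaves the size open), that is, nothing beyond the usual scatter. Compound 3 is expected to give about 100000 nM in this assay, within a range from 30000 nM to 300000 nM, with a real chance that it too returns only a limit.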

Compound 3, half-maximal inhibitory concentration: 2700 nM
For compound 3 the middle estimate is 37-fold (1.57 log units) above the measured one; the measured number lies below the stated range.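

In this assay, this position proves able to carry measurable activity: 4-bromophenyl in place of isopropyl on the aromatic nitrogen gives an at least 37-fold lower number from compound 1 to compound 3 (1.56 log units; beyond the scatter), a large step that the two earlier compounds, with no number between them, could not reveal. A ring on this nitrogen is not shown to be enough in every form, since compound 2, with a phenylsulfonyl group at the same place, returns only a limit of the assay, > 100000 nM. The step from compound 1 gives a minimum and not an exact size, since compound 1 also returns only a limit, so the full gain stays unknown: the limit of > 100000 nM in this assay, at which 2 of the 3 values shown sit.

What the compounds shown leave open is whether the gain depends on the bromine or on the directly attached aromatic ring, as they include no plain phenyl, 4-chlorophenyl or 4-methoxyphenyl group on this nitrogen. They also leave open how much of the activity of compound 3 depends on the methoxy groups of the shared core, as none of the compounds shown carries a hydroxyl group or a hydrogen in place of one of them.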